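A few compounds are considered here, and "the series" means these few. Any claim that something is new, unique, unknown or untested is made for them only; others in the source may bear on it.

Measured in an ADME assay on IMR-90 cells (Homo sapiens) for cytotoxicity, read by CellTiter-Blue, with a stated time of 46 h (a lower number here means that less compound is needed, a higher number that more compound is needed for the effect), so far. Compound 1 `CC(C)(C)C1CCN(S(=O)(=O)c2ccc(NC(=O)c3ccc([N+](=O)[O-])o3)cc2)CC1` gives > 25000 nM, a limit. Compound 2 `O=C(Nc1ccc(S(=O)(=O)N2CCC(Cl)CC2)cc1)c1ccc([N+](=O)[O-])o1` gives > 25000 nM, a limit. Compound 3 `N=C1CCN(S(=O)(=O)c2ccc(NC(=O)c3ccc([N+](=O)[O-])o3)cc2)CC1` gives > 25000 nM, a limit.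

Compound 1 therefore stands only at a limit in this assay, as do the other two values (the limit of > 25000 nM in this assay, at which 3 of the 3 values shown sit). The measured steps, a step that the two limits leave unreadable from compound 1 to compound 2, a step that the two limits leave unreadable from compound 1 to compound 3 and a step that the two limits leave unreadable from compound 2 to compound 3, all concern the group on the sulfonyl sulfur and none can be read in size.

Compound 4 `CC(C)(C)C1CCN(S(=O)(=O)c2ccc(NC(=O)c3ccc([N+](=O)[O-])s3)cc2)CC1` differs from compound 1 by 5-nitrothiophen-2-yl in place of 5-nitrofuran-2-yl on a carbonyl carbon. For the measured compounds named here, no measured step touches this part of the shared core, so the only guide is that every value so far sits at the limit. The step from compound 1 to compound 4 is expected to be unreadable, a step that the limit leaves unreadable from compound 1 to compound 4. Compound 4 is estimated at 30000 nM, range 10000 nM to 100000 nM, most likely reported again as a limit.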

Compound 4, half-maximal effective concentration: > 25000 nM
Compound 4 gave a limit, no number (the forecaster's own chance of this, stated with the estimate: 80%); the middle value does not contradict the limit.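

No new step can be read: compound 1 and compound 4 both stand only at a limit, so 5-nitrothiophen-2-yl in place of 5-nitrofuran-2-yl has no readable size. The compounds shown leave open whether any change on the sulfonyl sulfur or the carbonyl carbon gives a value off the limit: the limit of > 25000 nM in this assay, at which 4 of the 4 values shown sit.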